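The source may hold more compounds than are shown below. What is called first, only, known or untested is meant among the compounds shown, and "the series" means these compounds.

Compound 1 `C=C1C(=O)O[C@H]2[C@H]1CC/C(COC(=O)Cn1cc(F)c(=O)[nH]c1=O)=C\CC[C@@]1(C)O[C@@H]21`: > 20000 nM (a limit of the assay, not a number)
Compound 2 `C=C1C(=O)O[C@H]2[C@H]1CC/C(COC(=O)Cn1cc(F)c(=O)n(Cc3ccccc3)c1=O)=C\CC[C@@]1(C)O[C@@H]21`: 4270 nM
Compound 3 `C=C1C(=O)O[C@H]2[C@H]1CC/C(COC(=O)Cn1cc(F)c(=O)n(Cc3cc(F)ccc3F)c1=O)=C\CC[C@@]1(C)O[C@@H]21`: 4610 nM

All three compounds were tested in a functional assay on Bel7402/5-FU cells (Homo sapiens) for antiproliferative activity, read by MTT assay, with a stated time of 72 h; on this read-out lower numbers stand for stronger inhibition and higher numbers for weaker inhibition. Compound 3, at 4610 nM, stands level with compound 2, at 4270 nM; the step between them is a 1.1-fold higher number from compound 2 to compound 3 (0.03 log units; within the scatter).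

Compound 4 `C=C1C(=O)O[C@H]2[C@H]1CC/C(COC(=O)Cn1cc(F)c(=O)n(CCC)c1=O)=C\CC[C@@]1(C)O[C@@H]21` is the next analogue, with ethyl in place of 2,5-difluorophenyl on a saturated chain carbon bound to an aromatic nitrogen. Cut one bond further out, this reads 2,5-difluorobenzyl to propyl.

Going by the values given here, two measured steps bear on this change. Benzyl in place of hydrogen on an aromatic nitrogen gave an at least 4.6-fold lower number from compound 1 to compound 2 (0.67 log units; beyond the scatter), and 2,5-difluorobenzyl in the same place gave an at least 4.3-fold lower number from compound 1 to compound 3 (0.63 log units; beyond the scatter). Both rest on the limit of compound 1. Among the compounds with values here, no measured compound carries a ringless chain there, so the expectation is loose. A modest move to a higher number is expected in this assay, an estimated 1.5-fold higher number from compound 3 to compound 4 (0.18 log units; within the scatter). For compound 4 the estimated value is 7000 nM, with an expected range of 3000 nM to 18000 nM.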

Compound 4, half-maximal inhibitory concentration: 9110 nM
Beside the measured number, compound 4's estimate is 1.3-fold (0.11 log units) below it, and the stated range covers the measured number.
By their numbers in this assay, from the lowest: compounds 2, 3 and 4 (each within the scatter of the next, the first and the last beyond it). At a limit, above all of these: compound 1.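

In this assay, the propyl chain gave an at least 2.1-fold lower number from compound 1 to compound 4 (0.34 log units; beyond the scatter), so a chain without a ring also moves the number at this position. Ethyl in place of phenyl on the saturated chain carbon gave a 2.1-fold higher number from compound 2 to compound 4 (0.33 log units; beyond the scatter), a modest step, while ethyl in place of 2,5-difluorophenyl gave a 2.0-fold higher number from compound 3 to compound 4 (0.30 log units; within the scatter), so losing the ring costs little here, and only the unfluorinated pair shows a step beyond the scatter. Compound 1 stands at a limit, not a number: the limit of > 20000 nM in this assay, at which 1 of the 4 values shown sits.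

As far as these compounds go, whether a longer chain, or a chain ending in an amine or a carboxylic acid, would sit with propyl or with the benzyl groups stays open. The full size of each step from hydrogen also stays unread.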